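The source may report more compounds than this note shows. Statements on the series, on what has been measured and on what is new or still open speak of the compounds shown alone.

Working notes on the series, step from compound 3 to compound 4.

Compound 3, `Nc1nc2cc(-c3nn(CCCCCC(=O)NO)c4ncnc(N)c34)ccc2o1`, gives 19000 nM in a functional assay on MDA-MB-231 cells (Homo sapiens) for inhibition, read by MTT assay, with a stated time of 72 h (on this read-out lower numbers stand for stronger inhibition and higher numbers for weaker inhibition), the highest of the two numbers in hand; its nearest neighbour is compound 1, `CNC(=O)CCCCCCCn1nc(-c2ccc3oc(N)nc3c2)c2c(N)ncnc21`, at 2900 nM. Compound 2, `Nc1ncnc2c1c(-c1cnc3[nH]ccc3c1)nn2CCCC(=O)NO`, gives only a limit, > 150000 nM, and stands apart (the limit of > 150000 nM in this assay, at which 1 of the 3 values shown sits).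

Compound 4 is `Nc1nc2cc(-c3nn(CCCCCCCCCC(=O)NO)c4ncnc(N)c34)ccc2o1`. The change from compound 3: 4-(hydroxycarbamoyl)butyl in place of hydroxycarbamoyl on a saturated chain carbon, five bonds along the chain from an aromatic nitrogen. Among the compounds with values here, no measured step isolates a chain extension with the hydroxycarbamoyl end retained. Within the data shown here, the only single step in hand, a 6.6-fold higher number from compound 1 to compound 3 (0.82 log units; beyond the scatter), changes the end group and the chain together; it shows that the longer-chain compound 1 gives the lower number, which points, weakly, toward a lower number for compound 4 on lengthening the chain. The size of that step is a guide only, since the end group also moved.

Compound 4 is therefore expected to give a modestly lower number, a 3.8-fold lower number from compound 3 to compound 4 (0.58 log units; beyond the scatter), with the estimate at 5000 nM and a range from 1500 nM to 20000 nM.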

Compound 4, half-maximal inhibitory concentration: > 50000 nM
Compound 4 gave a limit, no number; the forecaster's own chance of this, stated with the estimate: 5%; middle value at least 10-fold (1.00 log units) away from the limit.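

Compound 4 gives a limit and not a number: the limit of > 50000 nM in this assay, at which 1 of the 4 values shown sits. With the hydroxycarbamoyl end retained, the longer chain on this position goes toward weaker inhibition (an at least 2.6-fold higher number from compound 3 to compound 4 (0.42 log units; beyond the scatter)), so the two compounds with this end and this core give no support to a gain from lengthening the chain. The step from the methylcarbamoyl compound (an at least 17-fold higher number from compound 1 to compound 4 (1.23 log units; beyond the scatter)) is large, but it changes the end group and the chain together, so the lower number of compound 1 cannot be credited to chain length alone.

Still open, going by these compounds, is how far the end group and the chain length each count, which a methylcarbamoyl or carboxylic acid end on the chain of compound 4 would help to separate. On these data alone, a shorter chain carrying the hydroxycarbamoyl end on the core of compound 3 also remains open.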